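The compounds below may be only part of what the source reports. "The series", "measured", "known", "first", "only" and "open" are said of these compounds alone.

Compound 1 `Nc1ccccc1NC(=O)c1ccc(NC(=S)NCc2cncc(Br)c2)cc1` gives 39000 nM
Compound 2 `Nc1ccccc1NC(=O)c1ccc(CNC(=O)c2cc3cnccc3[nH]2)cc1` gives 48000 nM

Both numbers come from a functional assay on MDA-MB-231 cells (Homo sapiens) for cytotoxicity, read by MTT assay, with a stated time of 72 h; on this read-out lower numbers stand for stronger inhibition and higher numbers for weaker inhibition. Compound 1 shows the lower of the two numbers, but compound 2 sits within the scatter of it, so the two cannot be ranked. Compound 3 `Nc1ccccc1NC(=O)c1ccc(NC(=S)NCc2ccccc2F)cc1` differs from compound 1 in one place: 2-fluorophenyl in place of 5-bromopyridin-3-yl on a saturated chain carbon bound to an amide-type nitrogen. For the measured compounds named here, no measured pair shows this change, so the data give no direct guide to its effect. The step of a 1.0-fold higher number from compound 1 to compound 3 (0.01 log units; within the scatter) is expected to stay within the scatter. Compound 3 is estimated at 40000 nM, between 15000 nM and 100000 nM.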

Compound 3, half-maximal inhibitory concentration: > 100000 nM
Compound 3: no number, only a limit; the forecaster's own chance of this, stated with the estimate: 20%; at least 2.5-fold (0.39 log units) between middle value and limit.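

In this assay, exchanging 5-bromopyridin-3-yl for 2-fluorophenyl gives an at least 2.5-fold higher number from compound 1 to compound 3 (0.40 log units; beyond the scatter). This position is therefore sensitive to its group, even though both groups have 7 heavy atoms and one six-membered aromatic ring. Compound 3 gives > 100000 nM, which is a limit of the assay and not a number, so the step has only a lower bound: the limit of > 100000 nM in this assay, at which 1 of the 3 values shown sits.

As far as these compounds go, the ring nitrogen, the bromine and the fluorine all change together in this step, so their separate shares remain open. From the compounds shown here alone, how an unsubstituted benzyl group would compare at this place also remains open.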